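Methyl on the amine nitrogen of compound 3

The compounds below may be only part of what the source reports. "The series", "measured", "known", "first", "only" and "open" are said of these compounds alone.

compound 1 `CC[C@H](NC)C(=O)N[C@@H]1C(=O)N2[C@@H](CC[C@@H]1CN)CC[C@H]2C(=O)NC(c1ccccc1)c1ccccc1`: 542 nM
compound 2 `CC[C@H](NC)C(=O)N[C@@H]1C(=O)N2[C@@H](CC[C@@H]1CCN)CC[C@H]2C(=O)NC(c1ccccc1)c1ccccc1`: 2300 nM
compound 3 `CC[C@H](N)C(=O)N[C@@H]1C(=O)N2[C@@H](CC[C@@H]1CCNC(=O)c1ccccc1)CC[C@H]2C(=O)NC(c1ccccc1)c1ccccc1`: 930 nM

All of these values come from a functional assay on MDA-MB-231 cells (Homo sapiens) for cytotoxicity, read by MTT assay, with a stated time of 96 h; on this read-out lower numbers stand for stronger inhibition and higher numbers for weaker inhibition. In this assay, compound 3 at 930 nM lies within the scatter of compound 1, while compound 2 stands at a higher number, beyond the scatter from compound 3.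

The next structure is compound 4 `CC[C@H](NC)C(=O)N[C@@H]1C(=O)N2[C@@H](CC[C@@H]1CCNC(=O)c1ccccc1)CC[C@H]2C(=O)NC(c1ccccc1)c1ccccc1`, which carries methyl in place of hydrogen on an amine nitrogen, amino to methylamino: methyl in place of hydrogen on an amine nitrogen. Going by the values given here, no measured pair isolates this change. Compounds 1 and 2 carry the methylamino group and compound 3 the amino group, but they differ elsewhere too. Among the compounds with values here, the only measured step, a 4.2-fold higher number from compound 1 to compound 2 (0.63 log units; beyond the scatter), lies at another place in the molecule. It serves only as a loose gauge of how far a small edit can move this series, and it gives no direction.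

No step beyond the scatter is therefore expected in this assay. The expected step is a 1.3-fold lower number from compound 3 to compound 4 (0.12 log units; within the scatter). Compound 4 is estimated at 700 nM, with an expected range of 280 nM to 1800 nM.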

Compound 4, half-maximal inhibitory concentration: 210 nM
For compound 4 the middle estimate is 3.3-fold (0.52 log units) above the measured one; the measured number lies below the stated range.
By their numbers in this assay, from the lowest: compound 4; then compounds 1 and 3 (each within the scatter of the next); then compound 2.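

In this assay, going by these compounds alone, the change of amino to methylamino now has a direct measure with the rest of the molecule held constant: a 4.4-fold lower number from compound 3 to compound 4 (0.65 log units; beyond the scatter) is a step the earlier compounds, which differed elsewhere too, could not give. With methylamino held fixed, adding benzoyl gives an 11-fold lower number from compound 2 to compound 4 (1.04 log units; beyond the scatter) and benzamidomethyl in place of amino gives a 2.6-fold lower number from compound 1 to compound 4 (0.41 log units; beyond the scatter) in a second comparison, so compound 4 has the lowest number of the series shown. Nothing at hand accounts for these steps.

On these data alone, whether the methyl step carries over to the shorter aminomethyl side chain of compound 1 stays open. So does whether an ethyl on the amine nitrogen, or an acetyl in place of the benzoyl, would move the number further.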